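The compounds below may be only part of what the source reports. "The series", "measured", "known", "first", "only" and "open" are said of these compounds alone.

Going by the values given here, in an ADME assay on BJ cells (Homo sapiens), read by MTT assay, with a stated time of 72 h (a higher number here means a weaker inhibitor, a lower number a stronger inhibitor), compound 3, `COc1nc(N)nc2c1c(-c1cccs1)cn2[C@@H]1O[C@H](CO)[C@@H](O)[C@H]1O`, gives 99900 nM, the only actual number so far. Compound 1, `COc1ncnc2c1c(-c1ccccc1)cn2[C@@H]1O[C@H](CO)[C@@H](O)[C@H]1O`, reads > 100000 nM, which is a limit of the assay and not a number. Compound 2, `COc1nc(N)nc2c1c(-c1ccco1)cn2[C@@H]1O[C@H](CO)[C@@H](O)[C@H]1O`, reads > 100000 nM, again a limit. The picture is therefore dominated by one boundary: the limit of > 100000 nM in this assay, at which 2 of the 3 values shown sit.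

Compound 4, `COc1nc(N)nc2c1c(-c1ccccc1)cn2[C@@H]1O[C@H](CO)[C@@H](O)[C@H]1O`, is the next to be read, and it differs from compound 3 by phenyl in place of thiophen-2-yl on an aromatic carbon. Among the compounds with values here, the one measured step that bears on this swap of aromatic groups at that place is a number no higher from compound 2 to compound 3 (the limit leaves the size open). Within the data shown here, its size stays open, as it starts from a limit, and no measured step has phenyl entering at this place with the rest of the structure unchanged.

No step beyond the scatter is expected in this assay, and no direction can be argued from these data. The expectation rests on compound 3 at 99900 nM. A reading at the limit of the assay would be no surprise. The expected step is a 1.0-fold higher number from compound 3 to compound 4 (0.00 log units; within the scatter). Compound 4 is estimated at 100000 nM, with an expected range of 45000 nM to 200000 nM.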

Compound 4, half-maximal inhibitory concentration: > 100000 nM
Compound 4: no number, only a limit (the forecaster's own chance of this, stated with the estimate: 60%); the middle value sits exactly at the limit.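

In this assay compound 4 gives > 100000 nM, which is a limit of the assay and not a number. Phenyl at this place, on the core bearing the amino group, reads only as a limit, as furan-2-yl does in compound 2, and the one directional statement available is a number no lower from compound 3 to compound 4 (the limit leaves the size open), while the steps from compound 2 and from compound 1 to compound 4 cannot be read. The effect of the amino group in place of hydrogen therefore remains unseen in this series, and the picture rests even more heavily on one boundary: the limit of > 100000 nM in this assay, at which 3 of the 4 values shown sit.

Going by these compounds alone, compound 3 remains the only compound with a number, at 99900 nM, and how far any group at this place can move the reading stays open. The compounds shown carry only aromatic rings at this place, and what an amine or a longer chain there would give remains open.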